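Adding a chloro to an amide-linked pyrazole series

This account rests on a few compounds, and the source may have more. Where it says the series, first, only, none or still open, it means among the compounds named here.

The compounds here share one core and differ only in the group hanging from the amide or urea nitrogen. Compound 1 `COc1cc(-c2nn(-c3cccc(NC(=O)Nc4cc(C(F)(F)F)cc(C(F)(F)F)c4)c3)cc2-c2ccncc2)ccc1Cl` carries a urea to a ring bearing two trifluoromethyl groups, and in a functional assay on UACC-62 cells (Homo sapiens) for inhibition, read by sulforhodamine B assay, with a stated time of 48 h (on this read-out higher numbers stand for lower toxicity in this test and lower numbers for higher toxicity in this test), compound 1 gives 3780 nM. Compound 2 `COc1cc(-c2nn(-c3cccc(NC(=O)c4cccc(C(F)(F)F)c4)c3)cc2-c2ccncc2)ccc1Cl` instead carries an amide to a 3-(trifluoromethyl)phenyl group. In this assay compound 2 reaches only a limit, > 50000 nM, so no number is known for it, only that it sits at the edge of what the test can report (the limit of > 50000 nM in this assay, at which 1 of the 2 values shown sits). The two values thus show compound 1 with a measured number and compound 2 with none.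

Compound 3 `COc1cc(-c2nn(-c3cccc(NC(=O)c4ccc(Cl)c(C(F)(F)F)c4)c3)cc2-c2ccncc2)ccc1Cl` is the next compound to be tested. It differs from compound 2 in one place: chloro in place of hydrogen on an aromatic carbon. Among the compounds with values here, no measured pair in this set isolates such a change, so the expectation rests on the structures alone. The step from compound 2 to compound 3 is expected to lower the number, roughly an at least 2.0-fold lower number from compound 2 to compound 3 (0.30 log units; that floor lies within the scatter), meaning higher toxicity in this test. Compound 3 is therefore estimated at 25000 nM, with a range from 6000 nM to 80000 nM.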

Compound 3, concentration lethal to 50% of the cells: > 32500 nM
Compound 3: no number, only a limit (the forecaster's own chance of this, stated with the estimate: 45%); at least 1.3-fold (0.11 log units) between middle value and limit.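

In this assay compound 2 gives only a limit, > 50000 nM. Compound 3 also gives only a limit, > 32500 nM. Within the data shown here, neither is a number, so no step from compound 2 to compound 3 can be read. The compounds shown leave open whether chloro in place of hydrogen on the 3-(trifluoromethyl)phenyl group changes the value at all.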